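The source may hold more compounds than are shown below. What is called first, only, known or untested is meant among the compounds shown, and "the series" means these compounds.

Measured in an ADME assay on BHK-21 cells (Mesocricetus auratus) for cytotoxicity, read by MTT assay, with a stated time of 72 h (a higher number here means that more compound is tolerated, a lower number that less compound is tolerated), as half-maximal cytotoxic concentration:
- compound 1 (`Cc1ccc(NCc2cn(-c3ccccc3)nc2-c2ccc(C(F)(F)F)cc2)cc1`) gives 88000 nM as a number
- compound 2 (`Cc1ccc(NCc2cn(-c3ccccc3)nc2-c2ccccc2)cc1`) gives > 100000 nM as a limit
- compound 3 (`Brc1ccc(NCc2cn(-c3ccccc3)nc2-c2ccc(Br)cc2)cc1`) gives > 100000 nM as a limit

Compound 3 has no number, only the limit of > 100000 nM in this assay, at which 2 of the 3 values shown sit, and nothing finer can be read from it. The change to compound 4 (`Cc1ccc(NCc2cn(-c3ccccc3)nc2-c2ccc(Br)cc2)cc1`) is methyl in place of bromo on an aromatic carbon and turns (4-bromophenyl)amino into (4-methylphenyl)amino. Going by the values given here, no measured step covers this methyl in place of bromo. Among the compounds with values here, the only step on record is an at least 1.1-fold higher number from compound 1 to compound 2 (0.05 log units; that floor lies within the scatter) and it sits at a different place in the molecule, so it bears only indirectly. Compound 1 already carries the (4-methylphenyl)amino group and gives 88000 nM as a number. Compound 2 carries the same group and gives > 100000 nM as a limit. The expected change is an at least 1.1-fold lower number from compound 3 to compound 4 (0.04 log units; that floor lies within the scatter) and no step beyond the scatter is expected in this assay on this basis. The value expected for compound 4 is 90000 nM and the estimated range runs from 45000 nM to 130000 nM with a reported limit quite possible.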

Compound 4, half-maximal cytotoxic concentration: > 100000 nM
Compound 4: a limit, no number; the forecaster's own chance of this, stated with the estimate: 55%; at least 1.1-fold (0.04 log units) between middle value and limit.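

With (4-methylphenyl)amino in place of (4-bromophenyl)amino, this assay still yields no number: compound 4 gives > 100000 nM, which is a limit. Elsewhere in the molecule, bromo in place of trifluoromethyl gives an at least 1.1-fold higher number from compound 1 to compound 4 (0.05 log units; that floor lies within the scatter). The steps joining compound 4 to compound 3 and to compound 2 cannot be read because both ends of each are limits: the limit of > 100000 nM in this assay, at which 3 of the 4 values shown sit.

Going by these compounds, whether methyl and bromo at this position differ at all in this assay remains open, as neither compound 3 nor compound 4 has a number. Also open, on these data alone, is whether an amine or a carboxylic acid in place of that methyl would give a measurable value rather than another limit.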